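The source may report more compounds than this note shows. Statements on the series, on what has been measured and on what is new or still open speak of the compounds shown alone.

- Compound 1 `CCCCOc1ccc2c(N3CCNCC3)cc(=O)oc2c1C`: 2790 nM
- Compound 2 `CCOCOc1ccc2c(N3CCNCC3)cc(=O)oc2c1C`: 1800 nM
- Compound 3 `CSCCOc1ccc2c(N3CCNCC3)cc(=O)oc2c1C`: not yet measured

Both values come from a functional assay on a cell-free system (plasma, Homo sapiens) for inhibition, with Plasma (Rattus norvegicus) as the target; on this read-out lower numbers stand for stronger inhibition and higher numbers for weaker inhibition. Among the measured compounds shown here, in this read-out, compound 2 gives 1800 nM, level with compound 1, the only other measured compound. The two cannot be told apart, as the step between them shows: a 1.6-fold lower number from compound 1 to compound 2 (0.19 log units; within the scatter).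

Compound 3 keeps the shared core and alters only one chain: (methylsulfanyl)methyl in place of ethoxy on a saturated chain carbon bound to an oxygen on an aromatic ring. In words, (methylsulfanyl)methyl stands in place of ethoxy on a saturated chain carbon bound to an oxygen on an aromatic ring. Cut one bond further out, ethoxymethoxy becomes 2-(methylsulfanyl)ethoxy.

For the measured compounds named here, one measured step bears on this, a swap at the same place: a 1.6-fold lower number from compound 1 to compound 2 (0.19 log units; within the scatter). It stayed within the scatter, so no clear move in either direction is expected in this assay. Going by the values given here, that is thin evidence, since no measured compound carries the (methylsulfanyl)methyl group, and the range is kept wide. The expected change is a 1.1-fold higher number from compound 2 to compound 3 (0.05 log units; within the scatter), which is not expected to exceed the scatter. For compound 3 the estimated value is 2000 nM, with an expected range from 800 nM to 5000 nM.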

Compound 3, half-maximal inhibitory concentration: 1500 nM
Compound 3: middle estimate off by 1.3-fold (0.12 log units), on the high side; the range from low to high includes it.
By their numbers in this assay, from the lowest: compounds 3, 2 and 1 (each within the scatter of the next).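

In this assay, the sulfur-bearing chain behaves much like the ether chain it replaces: putting (methylsulfanyl)methyl in place of ethoxy leaves the two compounds level (a 1.2-fold lower number from compound 2 to compound 3 (0.08 log units; within the scatter)). The other listed comparison, methylsulfanyl in place of ethyl on a saturated chain carbon, two bonds along the chain from an oxygen on an aromatic ring, also stays within the scatter (a 1.9-fold lower number from compound 1 to compound 3 (0.27 log units; within the scatter)), so compounds 1, 2 and 3 cannot be told apart, and this position has so far tolerated a change of heavy atom within the chain without a clear shift, though no other kind of measurement is available to account for this flat result.

On these data alone, what remains open is whether this place responds to any change at all, since these three chains may simply be too alike to show a difference. An amine or a carboxylic acid at the end of the chain, or a much longer chain, would test this, and only such a compound could show whether the number at this position can move beyond the scatter in either direction.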